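This account rests on a few compounds, and the source may have more. Where it says the series, first, only, none or still open, it means among the compounds named here.

Working notes on the series. The shared core carries a substituted phenyl on a carbon with a double bond to nitrogen. Compound 1 `CC1=CC[C@H](C(C)(C)NC(=S)N/N=C/c2ccccc2Cl)CC1` gives 71300 nM in a functional assay on HT-29 cells (Homo sapiens) for inhibition, read by sulforhodamine B assay, with a stated time of 48 h; a higher number here means a weaker inhibitor of growth, a lower number a stronger inhibitor of growth. Compound 2 `CC1=CC[C@H](C(C)(C)NC(=S)N/N=C/c2cccc(Cl)c2)CC1` differs by 3-chlorophenyl in place of 2-chlorophenyl on a carbon with a double bond to nitrogen, and in this assay compound 2 gives 7900 nM, a step of a 9.0-fold lower number from compound 1 to compound 2 (0.96 log units; beyond the scatter). Compound 3 `CC1=CC[C@H](C(C)(C)NC(=S)N/N=C/c2ccccc2[N+](=O)[O-])CC1` differs from compound 1 by nitro in place of chloro on an aromatic carbon, and compound 3 gives 7900 nM, a step of a 9.0-fold lower number from compound 1 to compound 3 (0.96 log units; beyond the scatter); compounds 2 and 3 are level within the scatter.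

Compound 4 `CC1=CC[C@H](C(C)(C)NC(=S)N/N=C/c2cccc([N+](=O)[O-])c2)CC1` differs from compound 2 by nitro in place of chloro on an aromatic carbon. This is the same kind of change as from compound 1 to compound 3, but the place differs: ortho to a large group there, meta to a large group here. Because compound 2 already stands at 7900 nM, a smaller step than a 9.0-fold lower number from compound 1 to compound 3 (0.96 log units; beyond the scatter) is expected, estimated as a 2.0-fold lower number from compound 2 to compound 4 (0.30 log units; within the scatter). Compound 4 is expected at about 4000 nM, likely between 1000 nM and 15000 nM.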

Compound 4, concentration for 50% growth inhibition: 600 nM
For compound 4 the middle estimate is 6.7-fold (0.82 log units) above the measured one; measured number outside the range, below it.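

Nitro in place of chloro on an aromatic carbon gives a 13-fold lower number from compound 2 to compound 4 (1.12 log units; beyond the scatter) in this assay, and the size of this step holds across the two cores: the same change on two cores in this assay, a 9.0-fold lower number (0.96 log units; beyond the scatter) from compound 1 to compound 3 and a 13-fold lower number (1.12 log units; beyond the scatter) from compound 2 to compound 4, 1.5-fold (0.16 log units) apart, within the scatter of two such steps

The change therefore carries between the core of compound 1 and the core of compound 2 with no difference that can be read beyond the scatter. These two pairs, in a single assay, do not show that it would carry to any other core, and they do not explain the step.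

Open, as far as these compounds go, is whether a nitrile or an amine on the same aromatic carbon would follow nitro or chloro. Also open, from the compounds shown here alone, is whether the step would survive a carbonyl in place of the thiocarbonyl.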